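Swapping amino for fluoro on a purine-like core

This account rests on a few compounds, and the source may have more. Where it says the series, first, only, none or still open, it means among the compounds named here.

Measured so far:
Compound 1 `CC(=O)OC(C)n1cnc2c(S)nc(N)nc21`: 128000 nM
Compound 2 `CC(=O)OCCOn1cnc2c(S)nc(N)nc21`: 3200 nM
Compound 3 `CC(=O)OC(C)n1cnc2c(S)nc(F)nc21`: 226000 nM

Of the compounds shown here, three have been tested in a functional assay on L1210 cells (Mus musculus) for inhibition; a lower number here means a stronger inhibitor, a higher number a weaker inhibitor. Compound 1 and compound 3 share a core and differ only where an amino group has been exchanged for a fluorine: fluoro in place of amino on an aromatic carbon. That exchange gave a 1.8-fold higher number from compound 1 to compound 3 (0.25 log units; within the scatter), so in this assay the two compounds cannot be told apart with confidence. Compound 2 carries a different side chain from compound 1; the difference between these two cores is not broken down here. In this assay compound 2 gives the lowest of the three numbers, and the gaps to compound 1 and compound 3 are beyond the usual scatter.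

Compound 4 `CC(=O)OCCOn1cnc2c(S)nc(F)nc21` has not yet been measured. It relates to compound 2 exactly as compound 3 relates to compound 1, with the same change at the same place: fluoro in place of amino on an aromatic carbon. Because the earlier step was a 1.8-fold higher number from compound 1 to compound 3 (0.25 log units; within the scatter), the step from compound 2 to compound 4 is expected to be small as well, about a 1.8-fold higher number from compound 2 to compound 4 (0.26 log units; within the scatter). Compound 4 is therefore estimated to give 5800 nM in this assay, with a likely range from 1500 nM to 25000 nM.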

Compound 4, half-maximal inhibitory concentration: 40000 nM
Beside the measured number, compound 4's estimate is 6.9-fold (0.84 log units) below it; measured number outside the range, above it.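

In this assay, putting fluoro in place of amino on the core of compound 2 gave a 13-fold higher number from compound 2 to compound 4 (1.10 log units; beyond the scatter), which is a large step. The same exchange therefore did not carry over at the same size from one core to the other: the same change on two cores in this assay, a 1.8-fold higher number (0.25 log units; within the scatter) from compound 1 to compound 3 and a 13-fold higher number (1.10 log units; beyond the scatter) from compound 2 to compound 4, 7.1-fold (0.85 log units) apart, beyond the scatter of two such steps. This shows that in this series the size of the step cannot simply be transferred between these two cores, but two pairs of compounds do not show which part of the side chains matters or why the steps differ, and they give no rule for any further core.

The compounds shown leave open how a chloro group or a methylamino group in the same place would behave on each of the two cores. They also leave open whether, on a core with a longer side chain, the exchange of amino for fluoro would give a small step or a large one.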